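Shortening the Phenylalkyl Amine on the Shared Core

The source may report more compounds than this note shows. Statements on the series, on what has been measured and on what is new or still open speak of the compounds shown alone.

Compound 2 `CSc1nc(-c2ccc(F)cc2)c(-c2ccnc(NC(C)CCc3ccccc3)c2)[nH]1` carries a 1-methyl-3-phenylpropyl group on a nitrogen attached to an aromatic ring of the shared core. In an assay on isolated protein for inhibition of Rho-associated protein kinase 2 (Homo sapiens), tested at 10 uM (a lower number here means less inhibition, a higher number more inhibition at the concentration tested (going by the name of the read-out)), compound 2 gives 0%. Compound 1 `CSc1nc(-c2ccc(F)cc2)c(-c2ccnc(NC3CCc4ccccc43)c2)[nH]1`, which bears a 2,3-dihydro-1H-inden-1-yl group on that nitrogen, gives 0% in this assay, and the step of no change at the digits printed from compound 1 to compound 2 (within the scatter) shows that exchanging these two groups leaves the read-out flat. Compound 3 `COCCn1c(SC)nc(-c2ccc(F)cc2)c1-c1ccnc(NC2CCCCC2)c1` differs from compound 2 at several places. In this assay compound 3 gives 7%, a value that lies within the usual scatter of compound 2. Going by the values given here, compound 2 thus stands level with compound 1 at the low end of the three numbers known.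

Compound 4 `CCC(Nc1cc(-c2[nH]c(SC)nc2-c2ccc(F)cc2)ccn1)c1ccccc1` differs from compound 2 in one place: 1-phenylpropyl in place of 1-methyl-3-phenylpropyl on a nitrogen on an aromatic ring. Among the compounds with values here, the only measured step that touches this nitrogen, no change at the digits printed from compound 1 to compound 2 (within the scatter), produced no change, and nothing among the measured compounds suggests that a 1-phenylpropyl group would behave differently from the other alkyl and aryl groups tried there. The step of a number 2 percentage points higher from compound 2 to compound 4 (within the scatter) is therefore expected to be none beyond the scatter. Compound 4 is estimated to give 2% in this assay, with a range from 0% to 12%.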

Compound 4, a percentage reported as inhibition, at one concentration (the size of the read-out at that concentration, not a potency): 0%
For compound 4 the middle estimate is 2 percentage points above the measured one; the measured number falls inside the stated range.
By their numbers in this assay, from the lowest: compounds 1, 2, 4 and 3 (each within the scatter of the next).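

With the 1-phenylpropyl group, a third group carrying a phenyl ring now sits on this nitrogen, and the reading in this assay remains flat: the change gives no change at the digits printed from compound 2 to compound 4 (within the scatter) and, set against the fused 2,3-dihydro-1H-inden-1-yl group, it gives no change at the digits printed from compound 1 to compound 4 (within the scatter) as well. Across compounds 1, 2 and 4, then, neither removing one carbon from the open chain nor opening the fused ring moves the number at the concentration tested, so the earlier single step no longer stands alone. No measurement given here bears on why these three groups read alike.

Since all three compounds rest at the same bottom reading, the series cannot show whether these groups differ from one another in any way that a single-concentration test would miss. As far as these compounds go, whether a group on this nitrogen bearing a primary amine or a carboxylic acid, or a phenyl ring held on a longer chain, would lift the reading on the shared core remains open.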